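Inverting one stereocentre from compound 2 to compound 3

The source may hold more compounds than are shown below. What is called first, only, known or untested is meant among the compounds shown, and "the series" means these compounds.

Two members of the series have readings so far, both in a functional assay on K562 cells (Homo sapiens) for cytotoxicity, read by MTT assay, with a stated time of 48 h; on this read-out higher numbers stand for weaker inhibition and lower numbers for stronger inhibition. Compound 1 (`CCOC(=O)[C@@]1(C(=O)Nc2ccccc2)C[C@@H]1c1cc(OC)c(OC)c(OC)c1`) gives > 100000 nM, which is a limit of the assay and not a number. Compound 2 (`CCOC(=O)[C@@]1(C(=O)NCc2ccc(C)cc2)C[C@H]1c1cc(OC)c(OC)c(OC)c1`) gives > 100000 nM, which is also a limit and not a number. Compound 2 therefore has no numeric position in the series, and the data so far amount to the limit of > 100000 nM in this assay, at which 2 of the 2 values shown sit.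

Compound 3 (`CCOC(=O)[C@@]1(C(=O)NCc2ccc(C)cc2)C[C@@H]1c1cc(OC)c(OC)c(OC)c1`) is the next compound to be read against compound 2: the two compounds have the same atoms and bonds and differ only in configuration as drawn: 1 of 2 stereo elements differ; a stereocentre at a saturated ring carbon is drawn S in compound 2 and R in compound 3. Among the compounds with values here, no measured step between two compounds is available, so the size of such an inversion is not known. The expectation rests only on compound 2, whose reading is the limit > 100000 nM. The expected change is a number no higher from compound 2 to compound 3 (the limit leaves the size open), meaning no step beyond the scatter and no favoured direction. In this assay the expected value for compound 3 is 100000 nM, with an estimated range from 30000 nM to 300000 nM, and a limit rather than a number is the likeliest report.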

Compound 3, half-maximal inhibitory concentration: > 100000 nM
Compound 3 ended at the assay's limit (the forecaster's own chance of this, stated with the estimate: 80%); the middle value lies on the limit itself.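

No step can be read from compound 2 to compound 3 or from compound 1 to compound 3, because each reading is a limit of the assay and not a number: the limit of > 100000 nM in this assay, at which 3 of the 3 values shown sit.

The compounds shown leave open whether the configuration at the saturated ring carbon, or 4-methylbenzyl in place of phenyl on the amide-type nitrogen, changes the reading at all.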